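This account rests on a few compounds, and the source may have more. Where it says the series, first, only, none or still open, it means among the compounds named here.

In a functional assay (aorta) with Rattus norvegicus as the target (on this read-out higher numbers stand for weaker inhibition and lower numbers for stronger inhibition), compound 1 (`CCCN(CCC)CCCOc1ccc(S(=O)(=O)c2c(CC)cn3ccccc23)cc1`) gives 150 nM and compound 2 (`CCCCN(CCCC)CCCCCOc1ccc(S(=O)(=O)c2c(CC)cn3ccccc23)cc1`) gives 97.4 nM as its reading, so the two cannot be separated. Compound 3 (`CCc1cn2ccccc2c1S(=O)(=O)c1ccc(OCCCNC(C)(C)C)cc1`) differs from compound 2 at the amine end of the chain: (tert-butyl)amino in place of 2-(dibutylamino)ethyl on a saturated chain carbon, three bonds along the chain from an oxygen on an aromatic ring is the change. Going by the values given here, the only measured step, a 1.5-fold lower number from compound 1 to compound 2 (0.19 log units; within the scatter) in size, lies within the scatter, but no measured compound carries (tert-butyl)amino, so it is a loose guide. A moderately higher number is expected, with an estimated 3.1-fold higher number from compound 2 to compound 3 (0.49 log units; beyond the scatter) in this assay as the working figure. Compound 3 is estimated at 300 nM with an expected range from 80 nM to 1100 nM for now.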

Compound 3, half-maximal inhibitory concentration: 413 nM
Beside the measured number, compound 3's estimate is 1.4-fold (0.14 log units) below it; low and high end bracket the measured number.
By their numbers in this assay, from the lowest: compounds 2 and 1 (each within the scatter of the next); then compound 3.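

In this assay the amine end of the chain now proves sensitive to the group it carries: (tert-butyl)amino gives a number beyond the scatter against both earlier groups (a 4.2-fold higher number from compound 2 to compound 3 (0.63 log units; beyond the scatter); a 2.8-fold higher number from compound 1 to compound 3 (0.44 log units; beyond the scatter)). Compared with 2-(dibutylamino)ethyl, it brings fewer heavy atoms and one hydrogen-bond donor, and these two differences cannot be separated here. No measured evidence explains the rise. Still open, from the compounds shown here alone, is whether isopropylamino or piperidine at this place would follow compound 3 or the two earlier compounds. Going by these compounds, the effect of a longer chain with (tert-butyl)amino also remains unknown.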